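The compounds below may be only part of what the source reports. "The series", "measured", "known", "first", "only" and "open" are said of these compounds alone.

Two compounds share the same core and differ only in their tail. Compound 1 `C[C@H](NC(=O)CN(c1nc(Cl)nc2[nH]cnc12)C1CC1)C(=O)OCc1ccccc1` gives 41.2% in a functional assay on the whole organism (Tail, strain ICR) with Mus musculus as the target, in the tail flick test, with a stated time of 30 min, at a dose of 25 umol/kg by the oral route (on this read-out higher numbers stand for a stronger effect at the one dose given and lower numbers for a weaker effect), the higher of the two numbers on record, though compound 2 `O=C(OCc1ccccc1)[C@@H]1CCCN1C(=O)CN(c1nc(Cl)nc2[nH]cnc12)C1CC1` gives 33.2%, a value within the scatter of compound 1, so no real difference between them can be claimed. Compound 3 `N=C(N)NCCC[C@H](NC(=O)CN(c1nc(Cl)nc2[nH]cnc12)C1CC1)C(=O)OCc1ccccc1` has not yet been measured. It differs from compound 1 by a group of 6 heavy atoms (3 carbon, 3 nitrogen; no ring) in place of a hydrogen atom, on a saturated chain carbon, two bonds along the chain from an amide-type nitrogen and a carbonyl carbon. Among the compounds with values here, no measured pair shows a change of this kind, so the step of a number 5.2 percentage points lower from compound 1 to compound 3 (within the scatter) is expected to be small, with no direction beyond the scatter favoured. Compound 3 is therefore estimated at 36%, with a range from 12% to 62%.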

Compound 3, a percentage reported as activity, at one dose (the size of the read-out at that dose, not a potency): 23.2%
Estimate against measurement, compound 3: 12.8 percentage points above; low and high end bracket the measured number.
By their numbers in this assay, from the lowest: compounds 3, 2 and 1 (each within the scatter of the next, the first and the last beyond it).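

Placing this group on the saturated chain carbon, two bonds along the chain from an amide-type nitrogen and a carbonyl carbon, gives the first change beyond the scatter in this assay, a number 18 percentage points lower from compound 1 to compound 3 (beyond the scatter). This position is therefore not indifferent to what it carries, and here the larger group goes with a weaker effect at the one dose given. Nothing available explains this loss.

As far as these compounds go, whether the loss follows the nitrogen-rich end of the group or the chain alone stays open. A plain propyl chain or an aminobutyl chain on this carbon would separate the two.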